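The source may report more compounds than this note shows. Statements on the series, on what has been measured and on what is new or still open speak of the compounds shown alone.

Measured in a toxicity assay on microsomes from liver (Homo sapiens) for metabolic stability, read by LC-MS, using NADPH, tested at 1 uM; on this read-out lower numbers stand for slow clearance and higher numbers for fast clearance:
- Compound 1 `CCOc1ncc(-c2nc(C(F)(F)F)sc2N2CCN(C(=O)Cn3ccc4cnccc43)[C@H](C)C2)cn1`: 656 mL.min-1.g-1
- Compound 2 `CCOc1ncc(-c2nc(C(F)(F)F)sc2N2CCN(C(=O)Cn3cnc(C(F)(F)F)n3)[C@H](C)C2)cn1`: < 10 mL.min-1.g-1, a limit of the assay
- Compound 3 `Cc1ncc(-c2nc(C(F)(F)F)sc2N2CCN(C(=O)Cn3nc(C)nc3C)[C@H](C)C2)cn1`: < 10 mL.min-1.g-1, a limit of the assay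

Compound 3 stands at the limit of < 10 mL.min-1.g-1 in this assay, at which 2 of the 3 values shown sit. Its entry is therefore a limit and not a number.

Compound 4 `CCOc1ccc(-c2nc(C(F)(F)F)sc2N2CCN(C(=O)Cn3nc(C)nc3C)[C@H](C)C2)cn1` has 6-ethoxypyridin-3-yl in place of the 2-methylpyrimidin-5-yl of compound 3, on an aromatic carbon: 6-ethoxypyridin-3-yl in place of 2-methylpyrimidin-5-yl on an aromatic carbon. The rest of the structure stays the same.

Among the measured compounds shown here, only one measured step is available, and it changes a different part of the molecule: an at least 65-fold lower number from compound 1 to compound 2 (1.81 log units; beyond the scatter). It says nothing directly about this exchange, but it shows that a single change in this series can move the read-out in this assay a long way. For the measured compounds named here, with no measured step at this place, a moderate move towards faster clearance seems the most reasonable expectation, far smaller than that step.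

The estimated change is an at least 2.0-fold higher number from compound 3 to compound 4 (0.30 log units; that floor lies within the scatter).

For compound 4 the expected value is 20 mL.min-1.g-1, with an estimated range from 7 mL.min-1.g-1 to 70 mL.min-1.g-1.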

Compound 4, intrinsic clearance in microsomes: 66 mL.min-1.g-1
The estimate for compound 4 lay 3.3-fold (0.52 log units) below the measured number, and the stated range covers the measured number.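

In this assay, putting 6-ethoxypyridin-3-yl in place of 2-methylpyrimidin-5-yl gives an at least 6.6-fold higher number from compound 3 to compound 4 (0.81 log units; beyond the scatter). Among the compounds shown here, this is the first measured sign that the aromatic carbon of the five-membered ring bearing this group matters for clearance, since the only earlier step changed the other end of the molecule. The true size of the step stays unknown, as compound 3 sits at a limit of the assay and not at a number: the limit of < 10 mL.min-1.g-1 in this assay, at which 2 of the 4 values shown sit.

The exchange alters both the six-membered ring and its chain, so the compounds shown leave open which of the two accounts for the rise. A 6-methylpyridin-3-yl group would separate the ring from the ethoxy chain, and an amine in place of the ethoxy chain would test whether any group there gives the same rise.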